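Arylsulfonyl hydrazides: sulfamoyl for methyl on compound 3

This account rests on a few compounds, and the source may have more. Where it says the series, first, only, none or still open, it means among the compounds named here.

Compound 1 `Cc1cccc(NNS(=O)(=O)c2ccc(C(=O)NCC(=O)O)cc2)c1`: 80 nM
Compound 2 `Cc1cccc(NNS(=O)(=O)c2ccc(S(C)(=O)=O)cc2)c1`: 43 nM
Compound 3 `CC(=O)Nc1ccc(S(=O)(=O)NNc2ccc(C)cc2)cc1`: 51 nM

In an assay for inhibition of Indoleamine 2,3-dioxygenase 1 (Homo sapiens), read by spectrophotometry, with stated times of 1 h and 4 h (on this read-out lower numbers stand for stronger inhibition and higher numbers for weaker inhibition), compound 3 gives 51 nM. Compound 2 gives 43 nM and compound 1 gives 80 nM; both lie within the scatter of compound 3, so the three measured numbers are not separated from one another.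

Compound 4 `CC(=O)Nc1ccc(S(=O)(=O)NNc2ccc(S(N)(=O)=O)cc2)cc1` is the next member. Relative to compound 3 the change is sulfamoyl in place of methyl on an aromatic carbon. Within the data shown here, the only measured step, a 1.9-fold lower number from compound 1 to compound 2 (0.27 log units; within the scatter), concerns a different group at a different site of the shared core and was itself within the scatter; it therefore gives little direct guidance on the present swap. Among the measured compounds shown here, no measured step speaks to exchanging a methyl for a sulfamoyl on the ring that carries the hydrazine nitrogen. With nothing pointing either way, no step beyond the scatter is expected in this assay.

Compound 4 is accordingly estimated at 60 nM, with a range of 20 nM to 180 nM, which corresponds to an expected step of a 1.2-fold higher number from compound 3 to compound 4 (0.07 log units; within the scatter).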

Compound 4, half-maximal inhibitory concentration: 2480 nM
Compound 4: middle estimate off by 41-fold (1.62 log units), on the low side, and the stated range ends below it.
By their numbers in this assay, from the lowest: compounds 2, 3 and 1 (each within the scatter of the next); then compound 4.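

In this assay, among these compounds, this position, on an aromatic carbon para to a large group, proves sensitive to substitution: sulfamoyl in place of methyl gives a 49-fold higher number from compound 3 to compound 4 (1.69 log units; beyond the scatter), the first step beyond the scatter. The earlier numbers, all within the scatter of one another, gave no sign that a single change on the shared core could have an effect of this size. Nothing available on the series accounts for this step.

Open is whether the step belongs to sulfamoyl specifically or would follow any group with more heavy atoms than methyl, as the compounds shown carry only these two groups at this position. An amine, a carboxylic acid or a chlorine on this carbon would begin to separate those readings.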